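The compounds below may be only part of what the source reports. "The series", "measured", "known", "first", "only" and "open" are said of these compounds alone.

Notes on the series sharing the core of compound 1 `Cc1nn(-c2nc(-c3ccc(Cl)c(Cl)c3)c(SC(C)C)s2)c(C(=O)O)c1-c1cncnc1`. In a functional assay on BJAB cells (Homo sapiens) for antiproliferative activity, with a stated time of 4 days (a lower number here means that less compound is needed, a higher number that more compound is needed for the effect), compound 1 gives 22000 nM. Compound 2 `Cc1cc(C#N)cc(-c2c(C)nn(-c3nc(-c4ccc(Cl)c(Cl)c4)c(SC(C)C)s3)c2C(=O)O)c1` gives 4800 nM in this assay, and compound 3 `COc1ccccc1-c1c(C)nn(-c2nc(-c3ccc(Cl)c(Cl)c3)c(SC(C)C)s2)c1C(=O)O` gives 14700 nM. Among the three numbers compound 3 holds the second highest; its nearest neighbour is compound 1, separated by a 1.5-fold lower number from compound 1 to compound 3 (0.18 log units; within the scatter), and its furthest is compound 2, separated by a 3.1-fold higher number from compound 2 to compound 3 (0.49 log units; beyond the scatter).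

The next step changes the one position that varies across the three: pyridin-4-yl in place of 2-methoxyphenyl on an aromatic carbon. The product is compound 4 `Cc1nn(-c2nc(-c3ccc(Cl)c(Cl)c3)c(SC(C)C)s2)c(C(=O)O)c1-c1ccncc1`.

Two measured steps speak to this change. Compound 1 carries pyrimidin-5-yl at the same place, and the step of a 1.5-fold lower number from compound 1 to compound 3 (0.18 log units; within the scatter) was within the scatter, so a six-membered ring with nitrogen and the 2-methoxyphenyl ring gave comparable numbers. The step of a 4.6-fold lower number from compound 1 to compound 2 (0.66 log units; beyond the scatter) shows that 3-cyano-5-methylphenyl did lower the number, and a 3.1-fold higher number from compound 2 to compound 3 (0.49 log units; beyond the scatter) shows that 2-methoxyphenyl gave back part of that gain. Pyridin-4-yl resembles pyrimidin-5-yl more than either carbon-only ring, so for compound 4 in this assay a step of a 1.2-fold higher number from compound 3 to compound 4 (0.09 log units; within the scatter) is expected, within the scatter or a slight rise toward compound 1. Compound 4 is therefore estimated at 18000 nM, with a range of 7000 nM to 45000 nM.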

Compound 4, half-maximal effective concentration: 5900 nM
For compound 4 the middle estimate is 3.1-fold (0.48 log units) above the measured one, and the stated range ends above it.
By their numbers in this assay, from the lowest: compounds 2 and 4 (each within the scatter of the next); then compounds 3 and 1 (each within the scatter of the next).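

In this assay pyridin-4-yl and pyrimidin-5-yl do not give the same result at this position (a 3.7-fold lower number from compound 1 to compound 4 (0.57 log units; beyond the scatter)), so two six-membered aromatic rings that both carry ring nitrogen can still differ beyond the scatter. Pyridin-4-yl also separates from 2-methoxyphenyl (a 2.5-fold lower number from compound 3 to compound 4 (0.40 log units; beyond the scatter)) but stays level with 3-cyano-5-methylphenyl (a 1.2-fold higher number from compound 2 to compound 4 (0.09 log units; within the scatter)), which shows that the lower pair of numbers can be reached without the substituted carbon-only ring. Ring type therefore does not sort the four compounds: compound 2 with a carbon-only ring and compound 4 with a nitrogen-containing ring form the lower pair, while compound 3 with a carbon-only ring and compound 1 with a nitrogen-containing ring form the higher pair, and nothing measured here accounts for these differences.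

Still open, as far as these compounds go, is how much depends on where the ring nitrogen sits, as pyridin-3-yl or pyridin-2-yl would test on the same core. The compounds shown also leave open whether an amino group on the pyridine ring, or a saturated ring such as piperidin-4-yl in its place, would keep the number of compound 4.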